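Branching the nitrogen chain: from isobutyl to 1-butylpentyl

This account rests on a few compounds, and the source may have more. Where it says the series, first, only, none or still open, it means among the compounds named here.

Three compounds have been measured in an assay on Prostate gland for inhibition of steroid 5-alpha-reductase (Rattus norvegicus); on this read-out higher numbers stand for weaker inhibition and lower numbers for stronger inhibition:
compound 1 `CCCCCCn1ccc2cc(/C(C)=C/C(=O)Nc3ccccc3OCCCC(=O)O)ccc21` gives 77 nM
compound 2 `C/C(=C\C(=O)Nc1ccccc1OCCCC(=O)O)c1ccc2c(ccn2CC(C)C)c1` gives 160 nM
compound 3 `CCCC(CC)n1ccc2cc(/C(C)=C/C(=O)Nc3ccccc3OCCCC(=O)O)ccc21` gives 9.3 nM

Compound 2 stands highest of the three numbers; compound 1 is nearest, separated by a 2.1-fold higher number from compound 1 to compound 2 (0.32 log units; beyond the scatter), and compound 3 furthest, separated by a 17-fold lower number from compound 2 to compound 3 (1.24 log units; beyond the scatter). Compound 4 `CCCCC(CCCC)n1ccc2cc(/C(C)=C/C(=O)Nc3ccccc3OCCCC(=O)O)ccc21` differs from compound 2 by 1-butylpentyl in place of isobutyl on an aromatic nitrogen. Within the data shown here, two measured steps bear on this change. The step of a 17-fold lower number from compound 2 to compound 3 (1.24 log units; beyond the scatter) replaces the same isobutyl by a chain branched at the saturated chain carbon bound to the aromatic nitrogen, and the step of an 8.3-fold lower number from compound 1 to compound 3 (0.92 log units; beyond the scatter) sets such a branched chain against a straight one of like length. Both move downward in this assay, the first by a large margin. The group entering compound 4 is likewise branched at that carbon, and longer still. On that basis a step well beyond the scatter is expected, downward, roughly of the size of the first of these two steps: the expected step is a 20-fold lower number from compound 2 to compound 4 (1.30 log units; beyond the scatter). Compound 4 is therefore expected to give about 8 nM in this assay, within a range from 2 nM to 30 nM.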

Compound 4, half-maximal inhibitory concentration: 21 nM
Compound 4: middle estimate off by 2.6-fold (0.42 log units), on the low side, and the stated range covers the measured number.
By their numbers in this assay, from the lowest: compound 3; then compound 4; then compound 1; then compound 2.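

In this assay the gain from a chain branched at the carbon bound to the aromatic nitrogen also appears with a second branched group: 1-butylpentyl in place of isobutyl lowers the number (a 7.6-fold lower number from compound 2 to compound 4 (0.88 log units; beyond the scatter)), and so does 1-butylpentyl in place of the straight hexyl (a 3.7-fold lower number from compound 1 to compound 4 (0.56 log units; beyond the scatter)). Longer arms on that branch do not extend the gain, since 1-butylpentyl in place of 1-ethylbutyl raises the number (a 2.3-fold higher number from compound 3 to compound 4 (0.35 log units; beyond the scatter)), which leaves compound 3 the strongest inhibitor of the four and shows that, among these groups, the size of the gain depends on the length of the arms as well as on the branching. Nothing measured here explains these shifts.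

As far as these compounds go, it remains open whether arms shorter than those of 1-ethylbutyl, as in 1-ethylpropyl, or a ring on the aromatic nitrogen, as in cyclohexyl, would fall below or above compound 3 in this assay on this scale. Also open, from the compounds shown here alone, is whether the same order of nitrogen groups would hold with a shorter chain carrying the carboxylic acid, since all four compounds share that chain.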